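The compounds below may be only part of what the source reports. "The series", "measured", "known", "first", "only" and "open" are said of these compounds alone.

Measured compounds:
compound 1 `Cc1nnc(SCC(=O)Nc2ccc(-c3nc(-c4ccccc4)c(-c4ccccc4)n3C)cc2)s1`: 67.8%
compound 2 `CCN1CCN(CC(=O)Nc2ccc(-c3nc(-c4ccccc4)c(-c4ccccc4)n3C)cc2)CC1`: 16.4%

In a functional assay on MCF7 cells (Homo sapiens) for cytotoxicity, read by MTT assay, with a stated time of 24 h, tested at 6.4 ug/mL (a lower number here means a weaker effect, a higher number a stronger effect of the compound at the concentration tested), compound 2 gives 16.4%, the lowest of the two numbers; its nearest neighbour is compound 1, which in this assay gives 67.8%. Among the compounds with values here, the only measured step is a number 51.4 percentage points lower from compound 1 to compound 2 (beyond the scatter), a large fall that swaps the whole group on the chain carbon bound to the carbonyl.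

Compound 3 `CN(C)/C=C/N1CCN(CC(=O)Nc2ccc(-c3nc(-c4ccccc4)c(-c4ccccc4)n3C)cc2)CC1` keeps the core and the piperazine of compound 2 and differs only by 2-(dimethylamino)ethenyl in place of ethyl on an amine nitrogen in a ring. Within the data shown here, no measured step touches that ring nitrogen: the one known step changes a different place and a different kind of group, so it gives no direct guide to the size or direction of this change. With no evidence either way, only a small step in this assay is expected, within or near the scatter, so compound 3 is expected to give 20% (range 5% to 45%), a step of a number 3.6 percentage points higher from compound 2 to compound 3 (within the scatter).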

Compound 3, a percentage reported as activity, at one concentration (the size of the read-out at that concentration, not a potency): 11.1%
Estimate against measurement, compound 3: 8.9 percentage points above; the measured number falls inside the stated range.
By their numbers in this assay, from the lowest: compounds 3 and 2 (each within the scatter of the next); then compound 1.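

Swapping ethyl for the larger 2-(dimethylamino)ethenyl on the ring nitrogen gives, in this assay, a number 5.3 percentage points lower from compound 2 to compound 3 (within the scatter), so this change at this place does not bring back the effect seen with compound 1. The second piperazine gives a number 56.7 percentage points lower from compound 1 to compound 3 (beyond the scatter), which shows that among these three compounds the low read-out holds with either of two different groups on the ring nitrogen, whenever a piperazine stands in place of the (5-methyl-1,3,4-thiadiazol-2-yl)sulfanyl group. Nothing measured here explains the fall from the thiadiazole compound to the piperazines.

From the compounds shown here alone, it remains open whether a longer chain ending in a carboxylic acid, or a plain hydrogen, on the ring nitrogen would behave the same way. Going by these compounds, it is also open whether an amine in place of the methyl on the thiadiazole would keep the effect of compound 1.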